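Removing one hydroxy from compound 1: an expected small step

A few compounds are considered here, and "the series" means these few. Any claim that something is new, unique, unknown or untested is made for them only; others in the source may bear on it.

Compound 1 `O=C(/C=C/C=C/c1ccccc1)c1ccccc1O` in a physicochemical assay, read by spectrophotometry, with a stated time of 20 min (a lower number here means a stronger inhibitor, a higher number a weaker inhibitor), gives 7130000 nM
Compound 2 `CN(C)c1ccc(-c2oc3cc(O)cc(O)c3c(=O)c2O)cc1` in this assay gives 612000 nM

Of these two numbers, compound 1 holds the higher and so stands as the weaker inhibitor. Compound 2 lies below it by a gap beyond the usual scatter. Compound 3 `O=C(/C=C/C=C/c1ccccc1)c1ccccc1` has not yet been measured in this assay. It departs from compound 1 by a single change: hydrogen in place of hydroxy on an aromatic carbon of a six-membered aromatic ring of carbon only, ortho to a large group.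

Within the data shown here, no two measured compounds differ in only one place, so the data hold no direct measure of this change. Compound 2 differs from compound 1 in more than this one place, and the gap between them cannot be carried over. The expectation is therefore cautious: an estimated step of a 1.4-fold higher number from compound 1 to compound 3 (0.15 log units; within the scatter), leaning toward a higher number but staying within the scatter. Compound 3 is expected to give about 10000000 nM, with an estimated range from 3500000 nM to 30000000 nM.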

Compound 3, half-maximal inhibitory concentration: 113000000 nM
Compound 3: the middle estimate sits 11-fold (1.05 log units) below what was measured; measured number outside the range, above it.
By their numbers in this assay, from the lowest: compound 2; then compound 1; then compound 3.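

Among these compounds, this is the first direct measure of the change: with only one place altered, putting hydrogen in place of the hydroxy on the aromatic carbon, ortho to a large group, gives in this assay a 16-fold higher number from compound 1 to compound 3 (1.20 log units; beyond the scatter). The step lies beyond the usual scatter, so this position is not indifferent to the exchange, and for this pair, the hydroxy goes with the stronger inhibition and hydrogen with the weaker. The data offer no independent measurement that bears on the size of this step, so what lies behind it remains unexplained.

The compounds shown leave open whether the hydroxy is specifically required, as they do not reveal what a methoxy, a carboxylic acid or an amine would give on the same aromatic carbon of the core of compound 1. They also leave open whether the same exchange of hydroxy for hydrogen would bring a step of similar size on a different core, since this single pair is the only measure of it.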